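Benzyloxy benzamide series: amine-bearing ring variants

The source may hold more compounds than are shown below. What is called first, only, known or untested is meant among the compounds shown, and "the series" means these compounds.

Compound 3 `CN(C(=O)c1ccccc1OCc1ccccc1)[C@@H]1CCNC1` reaches only a limit in an assay on HEK293 cells for inhibition of transient receptor potential cation channel subfamily M member 8 (Homo sapiens), read by FLIPR and calcium flux; on this read-out higher numbers stand for weaker inhibition and lower numbers for stronger inhibition: compound 3 gives > 10000 nM, which is the limit of > 10000 nM in this assay, at which 1 of the 3 values shown sits. Compound 1 `CCN(C(=O)c1ccccc1OCc1ccccc1)[C@@H]1CC[C@H](N)C1` is likewise reported only as a limit: in this assay compound 1 gives > 5000 nM, which is the limit of > 5000 nM in this assay, at which 1 of the 3 values shown sits. Compound 2 `CCN(C(=O)c1ccccc1OCc1ccccc1)C1CCCNC1` gives a number in this assay, 4860 nM. Going by the values given here, the single measured step, an at least 1.0-fold lower number from compound 1 to compound 2 (0.01 log units; that floor lies within the scatter), lies within the scatter. Compound 4 `NC1CCN(C(=O)c2ccccc2OCc2ccccc2)C1` differs from compound 3 by 3-aminopyrrolidin-1-yl in place of methyl(pyrrolidin-3-yl)amino on a carbonyl carbon. Among the compounds with values here, no measured step covers a change of this kind, and the one step on record stays within the scatter, so no shift beyond the scatter is expected; the step of a number no higher from compound 3 to compound 4 (the limit leaves the size open) is estimated to stay near zero. Compound 4 is expected to give about 10000 nM, estimated between 3000 nM and 30000 nM, with a limit a likely outcome.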

Compound 4, antagonist equilibrium constant: > 10000 nM
Compound 4: no number, only a limit; the forecaster's own chance of this, stated with the estimate: 70%; the middle value sits exactly at the limit.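

Compound 3 and compound 4 are both reported only as limits, so no step between them can be read: the limit of > 10000 nM in this assay, at which 2 of the 4 values shown sit.

The compounds shown leave open whether 3-aminopyrrolidin-1-yl in place of methyl(pyrrolidin-3-yl)amino shifts the number in this assay at all.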